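A few compounds are considered here, and "the series" means these few. Any claim that something is new, unique, unknown or untested is made for them only; others in the source may bear on it.

In a functional assay on P388 cells (Mus musculus) for cytotoxicity (a lower number here means a stronger inhibitor, a higher number a weaker inhibitor), compound 1 (`COc1ccc(C[C@H]2C(=O)N[C@@H](C)C(=O)N(C)[C@H]3Cc4ccc(cc4)Oc4cc(ccc4OC)C[C@@H](C(=O)N[C@H](C)C(=O)NC4(SCCS4)C(=O)N2C)N(C)C3=O)cc1`) gives 631 nM and compound 2 (`COc1ccc(C[C@H]2C(=O)N[C@@H](C)C(=O)N(C)[C@H]3Cc4ccc(cc4)Oc4cc(ccc4OC)C[C@@H](C(=O)N[C@H](C)C(=O)N[C@@H](CCSC)C(=O)N2C)N(C)C3=O)cc1`) gives 20.4 nM while compound 3 (`CCCCCN1C(=O)[C@@H](C)NC(=O)[C@@H]2Cc3ccc(OC)c(c3)Oc3ccc(cc3)C[C@@H](C(=O)N2C)N(C)C(=O)[C@H](C)NC(=O)[C@H](Cc2ccc(OC)cc2)N(C)C(=O)[C@@H]1C`) gives 21.4 nM in the same read-out. Compound 3 thus sits within the scatter of compound 2 and, beyond the scatter, on the stronger side of compound 1. Compound 4 (`COc1ccc(C[C@H]2C(=O)N[C@@H](C)C(=O)N(C)[C@H]3Cc4ccc(cc4)Oc4cc(ccc4OC)C[C@@H](C(=O)N[C@H](C)C(=O)N(CC=C(C)C)[C@@H](C)C(=O)N2C)N(C)C3=O)cc1`), not yet measured, carries 2-methylprop-1-en-1-yl in place of butyl on a saturated chain carbon bound to an amide-type nitrogen in a ring. Among the measured compounds shown here, no measured pair isolates this change, so in this assay the expectation for compound 4 rests on the level of compound 3 (21.4 nM). The estimated 1.2-fold higher number from compound 3 to compound 4 (0.07 log units; within the scatter) stays within the scatter. Compound 4 is expected at 25 nM with an estimated range from 8 nM to 80 nM in this series.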

Compound 4, half-maximal inhibitory concentration: 6.92 nM
Estimate against measurement, compound 4: 3.6-fold (0.56 log units) above; the whole stated range lies above it.
By their numbers in this assay, from the lowest: compound 4; then compounds 2 and 3 (each within the scatter of the next); then compound 1.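

In this assay 2-methylprop-1-en-1-yl in place of butyl on a saturated chain carbon bound to an amide-type nitrogen in a ring gives a 3.1-fold lower number from compound 3 to compound 4 (0.49 log units; beyond the scatter) and is the only single-place step shown. The position thus distinguishes two all-carbon groups of equal heavy-atom count, neither with hydrogen-bond donors or acceptors, and the entering group has a double bond outside aromatic rings. Nothing available explains the step. On these data alone, whether the double bond or the branching carries the step stays open. So does the reading of saturated 3-methylbutyl, a longer chain or an amine here.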